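Ester variation and microsomal half-life in one series

The source may report more compounds than this note shows. Statements on the series, on what has been measured and on what is new or still open speak of the compounds shown alone.

Of the compounds shown here, three sharing one core have been measured in an ADME assay (liver) for pharmacokinetics, with Liver microsome (Rattus norvegicus) as the target, using microsomes; a lower number here means that the compound disappears faster, a higher number that the compound lasts longer. Compound 2 `CCOC(=O)/C=C/c1ccc(NC(=O)C2(NC(=O)c3ccc4c(C5CCCC5)c(-c5ncc(Cl)cn5)n(C)c4c3)CCC2)cc1OCC` gives 3.07 h, the highest of the three. Compound 1 `CCOc1cc(NC(=O)C2(NC(=O)c3ccc4c(C5CCCC5)c(-c5ncc(Cl)cn5)n(C)c4c3)CCC2)ccc1/C=C/C(=O)OCOP(=O)(O)OC(C)(C)C` gives 0.133 h, and compound 3 `CCOc1cc(NC(=O)C2(NC(=O)c3ccc4c(C5CCCC5)c(-c5ncc(Cl)cn5)n(C)c4c3)CCC2)ccc1/C=C/C(=O)OCC(Cl)(Cl)Cl` gives 0.233 h. The step of a 23-fold higher number from compound 1 to compound 2 (1.36 log units; beyond the scatter) and the step of a 13-fold lower number from compound 2 to compound 3 (1.12 log units; beyond the scatter) both show that changing the group on the saturated chain carbon bound to an oxygen next to a carbonyl group away from the ethyl ester of compound 2 moves the half-life a long way down, while the difference between compound 1 and compound 3, a 1.8-fold higher number from compound 1 to compound 3 (0.24 log units; within the scatter), is small.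

Compound 4 `CCOc1cc(NC(=O)C2(NC(=O)c3ccc4c(C5CCCC5)c(-c5ncc(Cl)cn5)n(C)c4c3)CCC2)ccc1/C=C/C(=O)OCc1ccccc1` differs from compound 2 in the same place: phenyl in place of methyl on a saturated chain carbon bound to an oxygen next to a carbonyl group. For the measured compounds named here, no measured step concerns a benzyl ester, so the two large drops seen on leaving compound 2 are the only guide. On that basis a step beyond the scatter, downward, is expected, though smaller than the largest of the measured ones, and the estimated step is a 6.1-fold lower number from compound 2 to compound 4 (0.79 log units; beyond the scatter). The half-life of compound 4 in this assay is therefore estimated at 0.5 h, with a range from 0.15 h to 1.6 h.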

Compound 4, half-life: 2.17 h
For compound 4 the middle estimate is 4.3-fold (0.64 log units) below the measured one; measured number outside the range, above it.
By their numbers in this assay, from the lowest: compounds 1 and 3 (each within the scatter of the next); then compounds 4 and 2 (each within the scatter of the next).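

In this assay, for the compounds shown here, the change from ethyl to benzyl, phenyl in place of methyl on a saturated chain carbon bound to an oxygen next to a carbonyl group, gives a 1.4-fold lower number from compound 2 to compound 4 (0.15 log units; within the scatter), so compound 4 goes against the idea, drawn from the earlier compounds, that any move away from the ethyl ester costs half-life. The same position now shows a clear split, with a 9.3-fold higher number from compound 3 to compound 4 (0.97 log units; beyond the scatter) and a 16-fold higher number from compound 1 to compound 4 (1.21 log units; beyond the scatter), which places compound 2 and compound 4 together, apart from compound 1 and compound 3. Heavy-atom count does not order the results either, since trichloromethyl falls between methyl and phenyl on that count, yet a 13-fold lower number from compound 2 to compound 3 (1.12 log units; beyond the scatter) and compound 3 also lies beyond the scatter from compound 4. Nothing available accounts for this split.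

The compounds shown leave open how a free carboxylic acid, a longer chain such as butyl, or a phenethyl ester would behave at this place, and whether a chlorine or a methoxy group on the phenyl ring of compound 4 would keep its half-life. They also leave open whether the same order of esters would hold on a different core.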